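A few compounds are considered here, and "the series" means these few. Any claim that something is new, unique, unknown or untested is made for them only; others in the source may bear on it.

In an ADME assay on NIH3T3 cells (Mus musculus) for cytotoxicity (on this read-out lower numbers stand for an effect already at smaller amounts and higher numbers for an effect only at larger amounts of compound), the measured compounds read:

Compound 1 `COc1cccc(Nc2cccc(Cn3ccnc3)c2)c1`: > 100000 nM, which is a limit of the assay.
Compound 2 `Cc1cc(Oc2cccc(Cn3ccnn3)c2)cc(C)c1Cl`: 66800 nM
Compound 3 `Cc1cc(Oc2cccc(Cn3cncn3)c2)cc(C)c1Cl`: 75900 nM

Going by the values given here, compound 3 stands level with compound 2 within the scatter, and these two are the only exact numbers available. Compound 4 `Cc1cc(Oc2cccc(Cn3cccn3)c2)cc(C)c1Cl` differs from compound 3 by one exchange: 1H-pyrazol-1-yl in place of 1H-1,2,4-triazol-1-yl on a saturated chain carbon bound to an aromatic carbon. Among the compounds with values here, the one measured step bearing on this, a 1.1-fold higher number from compound 2 to compound 3 (0.06 log units; within the scatter), exchanged one five-membered aromatic ring for another at the same place, so no step beyond the scatter is expected in this assay. The expected step is a 1.2-fold lower number from compound 3 to compound 4 (0.07 log units; within the scatter). For compound 4 the estimated value is 65000 nM, with an expected range of 32000 nM to 100000 nM.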

Compound 4, half-maximal effective concentration: > 100000 nM
Compound 4: only a limit was reported; the forecaster's own chance of this, stated with the estimate: 15%; middle value at least 1.5-fold (0.18 log units) from the limit.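

In this assay, 1H-pyrazol-1-yl on the saturated chain carbon bound to an aromatic carbon gives only a limit of the assay, whereas the two triazolyl rings at this place gave exact numbers. The exchange reads as an at least 1.3-fold higher number from compound 3 to compound 4 (0.11 log units; that floor lies within the scatter) and as an at least 1.4-fold higher number from compound 2 to compound 4 (0.17 log units; that floor lies within the scatter), so both steps are floors and neither shows a change beyond the scatter. How far the true number of the pyrazolyl compound lies from the triazolyl ones cannot be read: the limit of > 100000 nM in this assay, at which 2 of the 4 values shown sit.

The compounds shown leave open whether any group at this place brings the number clearly lower. From the compounds shown here alone, an amine or a carboxylic acid in place of the ring remains untested here.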